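This account rests on a few compounds, and the source may have more. Where it says the series, first, only, none or still open, it means among the compounds named here.

Measured compounds:
compound 1 `Cc1nc(-c2cccnc2)sc1-c1nnc(-c2ccccc2Cl)o1` — > 100 ug/mL
compound 2 `COc1ccccc1-c1nnc(-c2sc(-c3cccnc3)nc2C)o1` — > 100 ug/mL

In an ADME assay on HCT-116 cells (Homo sapiens) for cytotoxicity, read by MTT assay (a higher number here means that more compound is tolerated, a lower number that less compound is tolerated), compound 2 gives > 100 ug/mL, a limit of the assay and not a number. Compound 1 likewise gives > 100 ug/mL, also a limit. Going by the values given here, both values sit at the limit of > 100 ug/mL in this assay, at which 2 of the 2 values shown sit, so the one measured step, a step that the two limits leave unreadable from compound 1 to compound 2, has no readable size. Compound 3 `Cc1nc(-c2cccnc2)sc1-c1nnc(-c2ccccc2)o1` differs from compound 2 by hydrogen in place of methoxy on an aromatic carbon. With nothing in this assay showing a step beyond the scatter, the step from compound 2 is expected to be a step that the limit leaves unreadable from compound 2 to compound 3, most likely again ending only at a limit. Compound 3 is estimated at 150 ug/mL (range 60 ug/mL to 400 ug/mL).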

Compound 3, half-maximal cytotoxic concentration: > 100 ug/mL
Compound 3: no number, only a limit (the forecaster's own chance of this, stated with the estimate: 85%); the middle value lies beyond the limit too.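

No step among compound 1, compound 2 and compound 3 can be read in this assay, since each gives a limit and not a number: the limit of > 100 ug/mL in this assay, at which 3 of the 3 values shown sit.

The compounds shown leave open whether chloro, methoxy or hydrogen on an aromatic carbon differ at all in how much compound is tolerated.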